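Swapping an aromatic ring for an open-chain amidine

This account rests on a few compounds, and the source may have more. Where it says the series, first, only, none or still open, it means among the compounds named here.

Compound 1 `c1ccc2c(c1)CC(CNCCCNC1=NCCCN1)O2`, an assay on isolated protein (Bos taurus) with 5-hydroxytryptamine receptor 1D (Homo sapiens) as the target; on this read-out higher numbers stand for weaker inhibition and lower numbers for stronger inhibition: 126 nM
Compound 2 `c1ccc2c(c1)CCC(CNCCCNc1ccncn1)O2`, this assay: 10 nM

Going by the values given here, of the two compounds measured so far, compound 2 gives the lower number in this assay, and compound 1 sits a clear distance away, beyond the usual scatter of repeated measurements. Compound 2 is therefore the reference point for the next step.

Compound 3 `CC(C)/N=C(\N)NNCCCNCC1CCc2ccccc2O1` keeps the shared core of compound 2 and changes only the group on the amine nitrogen at the end of the chain: a group of 7 heavy atoms (4 carbon, 3 nitrogen; no ring) in place of a group of 6 heavy atoms (4 carbon, 2 nitrogen; one six-membered aromatic ring with 2 hetero atoms), on an amine nitrogen. The aromatic ring that carried two hydrogen-bond acceptors is gone; in its place sits an open-chain group with a double bond outside any ring and two hydrogen-bond donors.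

Among the compounds with values here, no pair of measured compounds isolates this kind of change, so no measured step can be carried over directly. Compound 1, whose end group is also a non-aromatic, nitrogen-rich group, gave the weaker value of the two, which argues for a move to a higher number. The step from compound 2 to compound 3 is expected to be an 8.0-fold higher number from compound 2 to compound 3 (0.90 log units; beyond the scatter). Compound 3 is expected to give about 80 nM in this assay, within a range of 20 nM to 400 nM.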

Compound 3, half-maximal inhibitory concentration: 3.16 nM
Beside the measured number, compound 3's estimate is 25-fold (1.40 log units) above it; measured number below the stated range.
By their numbers in this assay, from the lowest: compound 3; then compound 2; then compound 1.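

In this assay, putting the open-chain group in place of pyrimidin-4-yl on the amine nitrogen gives a 3.2-fold lower number from compound 2 to compound 3 (0.50 log units; beyond the scatter), a modest gain in inhibition. Going by these compounds alone, this is the first direct reading of a change at this position, since compound 1 differs from compound 2 in its core as well as in its end group. For this pair, then, a low number does not depend on an aromatic ring at the end of the chain: compound 3 has no ring in this group and still inhibits more strongly than compound 2, although no measurement here bears on why the number fell.

This single swap changes several features at once, removing the ring and its two hetero atoms while adding a double bond outside any ring and two hydrogen-bond donors, so the pair cannot show which of these features matters. As far as these compounds go, it also remains open whether a phenyl ring, a simple primary amine or a longer chain between the two amine nitrogens would give a number as low as that of compound 3.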